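A few compounds are considered here, and "the series" means these few. Any claim that something is new, unique, unknown or untested is made for them only; others in the source may bear on it.

Compound 1 `CCC(c1ccc(-c2ccc(OC)cc2)cc1)c1cccnc1`. In an assay for inhibition of steroid 17-alpha-hydroxylase/17,20 lyase (Homo sapiens) (on this read-out lower numbers stand for stronger inhibition and higher numbers for weaker inhibition), compound 1 gives > 5000 nM, a limit of the assay rather than a number (the limit of > 5000 nM in this assay, at which 1 of the 3 values shown sits).
Compound 2 `CCC(c1ccncc1)c1ccc(-c2ccc(OC)cc2)cc1`. In this assay compound 2 gives 1610 nM.
Compound 3 `COc1ccc(-c2ccc(Cc3ccncc3)cc2)cc1F`. In this assay compound 3 gives 3340 nM.

Compound 3 stands highest of the two numbers in this assay; the nearest value, from compound 2, is lower and the gap lies beyond the scatter. Compound 4 `CC(C)(C)OC(=O)Nc1ccc(-c2ccc(Cc3ccncc3)cc2)cc1F` has not yet been measured. It differs from compound 3 by (tert-butoxycarbonyl)amino in place of methoxy on an aromatic carbon.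

Going by the values given here, only one measured step exists, an at least 3.1-fold lower number from compound 1 to compound 2 (0.49 log units; beyond the scatter), and it concerns the pyridine attachment on the chain carbon, not the group on the fluoro-bearing ring. Among the compounds with values here, no measured step touches the position changed here, so the expected size of the step to compound 4 in this assay cannot be anchored; an effect no larger than modest, in either direction, is expected. For compound 4 the estimate is 2500 nM, between 700 nM and 9000 nM, which is the expected step of a 1.3-fold lower number from compound 3 to compound 4 (0.13 log units; within the scatter) from compound 3.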

Compound 4, half-maximal inhibitory concentration: > 10000 nM
Compound 4 ended at the assay's limit; the forecaster's own chance of this, stated with the estimate: 30%; middle value at least 4.0-fold (0.60 log units) away from the limit.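

In this assay, the position on the aromatic carbon ortho to a fluoro group now has its first measured step, and the group it carries clearly matters: (tert-butoxycarbonyl)amino in place of methoxy gives an at least 2.9-fold higher number from compound 3 to compound 4 (0.47 log units; beyond the scatter). The earlier step concerned only the pyridine attachment on the chain carbon, so it said nothing about this position. Compound 4 stands at a limit of the assay and not at a number, so only a minimum is known for this step: the limit of > 10000 nM in this assay, at which 1 of the 4 values shown sits.

The compounds shown do not separate the tert-butoxy part of the entering group from its carbonyl or the nitrogen with its hydrogen. As far as these compounds go, a plain amine or a small acetamide at this place would tell these parts apart, and whether any group here improves on methoxy stays open.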